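The compounds below may be only part of what the source reports. "The series", "measured", "known", "first", "only" and "open" are said of these compounds alone.

Measured compounds:
compound 1, `CCC1(OC(=O)N2CCC(Oc3ncnc(Oc4ccc(S(C)(=O)=O)nc4C)c3F)CC2)CC1`, 333 nM
compound 2, `Cc1nc(S(C)(=O)=O)ccc1Oc1ncnc(OC2CCN(C(=O)SC(C)C)CC2)c1F`, 41.3 nM
compound 3, `Cc1nc(S(C)(=O)=O)ccc1Oc1ncnc(OC2CCN(C(=O)SC(C)(C)C)CC2)c1F`, 30.7 nM

All three were read in a functional assay on isolated protein for inhibition of Glucose-dependent insulinotropic receptor (Rattus norvegicus), read by HTRF and cAMP accumulation; a higher number here means that more compound is needed for the effect, a lower number that less compound is needed. Compound 3 gives the lowest of the three numbers there. Compound 2 is nearest to it, and the gap between them lies within the scatter: a 1.3-fold lower number from compound 2 to compound 3 (0.13 log units; within the scatter). Compound 1 is furthest away, with an 11-fold lower number from compound 1 to compound 3 (1.04 log units; beyond the scatter) and, to compound 2, an 8.1-fold lower number from compound 1 to compound 2 (0.91 log units; beyond the scatter).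

Compound 4, `Cc1nc(S(C)(=O)=O)ccc1Oc1ncnc(OC2CCN(C(=O)C3(F)CCC3)CC2)c1F`, has not yet been measured. It differs from compound 3 on a carbonyl carbon whose other neighbour is the amide-type nitrogen in a ring: a group of 5 heavy atoms (4 carbon, 1 fluorine; one four-membered non-aromatic ring of carbon only) in place of a group of 5 heavy atoms (4 carbon, 1 sulfur; no ring), on a carbonyl carbon.

Within the data shown here, the steps that bear on this change are the two from compound 1, both at the same carbonyl carbon, and both were sizeable: an 8.1-fold lower number from compound 1 to compound 2 (0.91 log units; beyond the scatter) and an 11-fold lower number from compound 1 to compound 3 (1.04 log units; beyond the scatter). The step of a 1.3-fold lower number from compound 2 to compound 3 (0.13 log units; within the scatter) shows that adding a methyl on the sulfur-bound chain made no difference beyond the scatter. None of the three steps involves a ring group with a fluorine at this carbonyl carbon, so the measured record does not cover the group that enters in compound 4 directly. Compound 4 is therefore expected to land between the number of compound 1 and that of compound 3, with a step estimated as a 2.3-fold higher number from compound 3 to compound 4 (0.36 log units; beyond the scatter). For compound 4 the estimate in this assay is 70 nM, with a range from 15 nM to 300 nM.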

Compound 4, half-maximal effective concentration: 123 nM
For compound 4 the middle estimate is 1.8-fold (0.24 log units) below the measured one, within the range that was stated.
By their numbers in this assay, from the lowest: compounds 3 and 2 (each within the scatter of the next); then compound 4; then compound 1.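

Among these compounds, on the carbonyl carbon whose other neighbour is the amide-type nitrogen in a ring, the group with a fluorine on a four-membered carbon ring reads in this assay as a 4.0-fold higher number from compound 3 to compound 4 (0.60 log units; beyond the scatter) and as a 3.0-fold higher number from compound 2 to compound 4 (0.47 log units; beyond the scatter), the first group without sulfur in this place to be set against the two sulfur-bearing ones. It still holds an advantage over the ethylcyclopropyl-bearing oxygen group, with a 2.7-fold lower number from compound 1 to compound 4 (0.43 log units; beyond the scatter), so a lower number than that of compound 1 at this carbonyl carbon does not require sulfur, although among these four compounds the two sulfur-bearing groups give the lowest numbers, and no compound goes against that order. No measurement at hand accounts for these differences.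

The change to compound 4 removes the sulfur and brings in the ring and the fluorine all at once, and the compounds shown leave open which of these accounts for the step. From the compounds shown here alone, a cyclobutyl group without the fluorine would address that question, and a tert-butoxy group or a longer chain on the sulfur at this carbonyl carbon also remains open.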